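A few compounds are considered here, and "the series" means these few. Any claim that something is new, unique, unknown or untested is made for them only; others in the source may bear on it.

Compound 1 `NCCCOc1ccc([C@H]2CC[C@]3(CC2)OOC2(O3)C3CC4CC(C3)CC2C4)cc1`: < 7 mL.min-1.g-1
Compound 2 `NC(=O)C1CCN(Cc2ccc([C@H]3CC[C@]4(CC3)OOC3(O4)C4CC5CC(C4)CC3C5)cc2)CC1`: 26 mL.min-1.g-1
Compound 3 `c1cc([C@H]2CC[C@]3(CC2)OOC2(O3)C3CC4CC(C3)CC2C4)ccc1OC1CCNCC1`: 10 mL.min-1.g-1

These results come from an ADME assay on microsomes from liver (Mus musculus) for metabolic stability, read by LC-MS, tested at 1 uM; a lower number here means slower removal, a higher number faster removal of the compound. The entry for compound 1, < 7 mL.min-1.g-1, is a limit of the assay and not a number. Of the two true numbers, the lower belongs to compound 3, at 10 mL.min-1.g-1. Among the measured compounds shown here, the only other number lies above it, and the step down to it is a 2.6-fold lower number from compound 2 to compound 3 (0.41 log units; beyond the scatter).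

Compound 4 `CC1(C)CC(O)(COc2ccc([C@H]3CC[C@]4(CC3)OOC3(O4)C4CC5CC(C4)CC3C5)cc2)CC(C)(C)N1` keeps the shared core and the oxygen on the aromatic ring, but changes the group on that oxygen: (4-hydroxy-2,2,6,6-tetramethylpiperidin-4-yl)methyl in place of piperidin-4-yl on an oxygen on an aromatic ring. In words, (4-hydroxy-2,2,6,6-tetramethylpiperidin-4-yl)methyl stands in place of piperidin-4-yl.

For the measured compounds named here, the closest precedent is an at least 1.4-fold higher number from compound 1 to compound 3 (0.15 log units; that floor lies within the scatter), which also swaps the group on that oxygen. Its floor lies within the scatter, so it gives no firm size. The larger steps, an at least 3.7-fold higher number from compound 1 to compound 2 (0.56 log units; beyond the scatter) and a 2.6-fold lower number from compound 2 to compound 3 (0.41 log units; beyond the scatter), replace the whole group on an aromatic carbon, so they show that this assay can respond to changes in this part of the molecule. However, they give no direction for the new group.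

No step beyond the scatter is therefore expected, and the estimated step is a 1.2-fold higher number from compound 3 to compound 4 (0.08 log units; within the scatter). For compound 4 the estimated value is 12 mL.min-1.g-1, with an expected range from 6 mL.min-1.g-1 to 30 mL.min-1.g-1.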

Compound 4, intrinsic clearance in microsomes: < 7 mL.min-1.g-1
Compound 4: no number, only a limit (the forecaster's own chance of this, stated with the estimate: 25%); middle value at least 1.7-fold (0.23 log units) away from the limit.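

In this assay, the swap on the oxygen on the aromatic ring gives an at least 1.4-fold lower number from compound 3 to compound 4 (0.15 log units; that floor lies within the scatter). Among the compounds shown here, this is the first sign that this position tolerates a far larger group, with 12 heavy atoms in place of 6, without a higher number. The earlier compounds shown here held only smaller groups on this oxygen, but the floor of this step lies within the scatter, so it shows no firm fall in removal, only that no rise appears. The step between compound 1 and compound 4 cannot be read, since both sit at the same limit of the assay, which is not a number: the limit of < 7 mL.min-1.g-1 in this assay, at which 2 of the 4 values shown sit.

On these data alone, how far the true values of compound 1 and compound 4 lie under that limit remains open, so the two groups cannot be ranked against each other. The new group also brings a hydroxy group and tetramethyl substitution together, and only a matched pair such as (4-hydroxypiperidin-4-yl)methyl, or 2,2,6,6-tetramethylpiperidin-4-yl, on the same oxygen could tell their contributions apart.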